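The compounds below may be only part of what the source reports. "The series", "measured", "known", "first", "only" and "open" are said of these compounds alone.

Compound 2 `COc1cccc(OC)c1C(=O)Nc1nnc(-c2ccc(I)cc2)s1` and compound 1 `COc1cccc(OC)c1C(=O)Nc1nnc(-c2ccc(C(C)C)cc2)s1` share one core and differ only at one aromatic carbon. In a functional assay on the whole organism (integument) for inhibition, with Chilo suppressalis as the target, read by scintillation counting, with a stated time of 72 h, in the presence of a further agent that is not named here (on this read-out lower numbers stand for stronger inhibition and higher numbers for weaker inhibition), compound 1 gives 182 nM, and compound 2 gives 97.7 nM, so the two stand within the scatter of each other: a 1.9-fold lower number from compound 1 to compound 2 (0.27 log units; within the scatter). Compound 3 `CCN(CC)c1ccc(-c2nnc(NC(=O)c3c(OC)cccc3OC)s2)cc1` changes the same aromatic carbon: diethylamino in place of iodo on an aromatic carbon. For the measured compounds named here, only that one measured step bears on this change, and it lay within the scatter, so no step beyond the scatter is expected in this assay: the estimated step is a 1.2-fold higher number from compound 2 to compound 3 (0.09 log units; within the scatter). Compound 3 is therefore expected to give about 120 nM, between 40 nM and 400 nM.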

Compound 3, half-maximal inhibitory concentration: 676 nM
Compound 3: middle estimate off by 5.6-fold (0.75 log units), on the low side, outside the stated range (above it).
By their numbers in this assay, from the lowest: compounds 2 and 1 (each within the scatter of the next); then compound 3.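

In this assay, this aromatic carbon does not accept every group alike: diethylamino brings a 6.9-fold higher number from compound 2 to compound 3 (0.84 log units; beyond the scatter), and against isopropyl it brings a 3.7-fold higher number from compound 1 to compound 3 (0.57 log units; beyond the scatter). Iodo and isopropyl had stood within the scatter of each other, so diethylamino is the one group of the three that separates from the others. Nothing measured here explains this difference. The compounds shown leave open whether the higher number goes with the nitrogen or with the two ethyl chains. Dimethylamino, or a plain carbon chain such as butyl, on this same carbon would help to separate the two.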